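Lengthening the chain: an estimate for compound 3

The compounds below may be only part of what the source reports. "The series", "measured", "known", "first", "only" and "open" are said of these compounds alone.

Going by the values given here, in a functional assay on A549 cells (Homo sapiens) for inhibition, read by MTT assay, with a stated time of 48 h (on this read-out higher numbers stand for weaker inhibition and lower numbers for stronger inhibition), compound 1 `COc1ccc(N(C)c2nc(C)nc3ccccc23)cc1C(=O)OCCC[Se]C#N` gives 250 nM and compound 2 `COc1ccc(N(C)c2nc(C)nc3ccccc23)cc1C(=O)OCCCC[Se]C#N` gives 155 nM so compound 2 stands within the scatter of the only other number available. Compound 3 `COc1ccc(N(C)c2nc(C)nc3ccccc23)cc1C(=O)OCCCCCC[Se]C#N` has the same core and differs from compound 2 by a group of 5 heavy atoms (3 carbon, 1 nitrogen, 1 selenium; no ring) in place of a group of 3 heavy atoms (1 carbon, 1 nitrogen, 1 selenium; no ring), on a saturated chain carbon, four bonds along the chain from an oxygen next to a carbonyl group at the end of the chain. The place is a saturated chain carbon, four bonds along the chain from an oxygen next to a carbonyl group. Among the compounds with values here, one measured step bears on this change: a 1.6-fold lower number from compound 1 to compound 2 (0.21 log units; within the scatter) is a change of the same kind and stays within the scatter. Within the data shown here, with only that step as a guide, no step beyond the scatter is expected in this assay and no firm direction can be read from it. The expected outcome is a 1.2-fold lower number from compound 2 to compound 3 (0.08 log units; within the scatter) on present evidence. Compound 3 is estimated at 130 nM with an expected range from 55 nM to 320 nM for this measurement.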

Compound 3, half-maximal inhibitory concentration: 488 nM
Compound 3: middle estimate off by 3.8-fold (0.57 log units), on the low side; the measured number lies above the stated range.
By their numbers in this assay, from the lowest: compounds 2, 1 and 3 (each within the scatter of the next, the first and the last beyond it).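

In this assay, going by these compounds alone, lengthening the chain gives the first step beyond the scatter at this saturated chain carbon (a 3.1-fold higher number from compound 2 to compound 3 (0.50 log units; beyond the scatter)): the group of 5 heavy atoms goes with weaker inhibition than the group of 3 heavy atoms it replaces. Compound 3 still cannot be separated from compound 1 (a 2.0-fold higher number from compound 1 to compound 3 (0.29 log units; within the scatter)), so compounds 1, 2 and 3 show no steady trend with chain length. Nothing available on these compounds accounts for the step.

From the compounds shown here alone, what a longer chain would do in this assay stays open, and so does whether the step depends on chain length alone. Also open, going by these compounds, is how an amine or a carboxylic acid would compare at the end of the chain.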